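This account rests on a few compounds, and the source may have more. Where it says the series, first, only, none or still open, it means among the compounds named here.

Measured so far in a functional assay on UACC-62 cells (Homo sapiens) for cytotoxicity, read by sulforhodamine B assay, with a stated time of 48 h, tested at 1 uM; a lower number here means a stronger effect, a higher number a weaker effect of the compound at the concentration tested:

compound 1 `COc1ccc(-c2cc(/C=C/C(=O)c3ccc(N)cc3)[nH]n2)cc1` gives 79%
compound 2 `COc1cc(-c2cc(/C=C/C(=O)c3ccc(Cl)c(Cl)c3)[nH]n2)cc(OC)c1OC` gives 96%
compound 3 `COc1cc(-c2cc(/C=C/C(=O)c3ccc(F)c(F)c3)[nH]n2)cc(OC)c1OC` gives 88%

Compound 1 stands lowest of these three numbers. Its gap to compound 3 is within the scatter, so the two cannot be told apart, while its gap to compound 2 lies beyond the scatter. Among the measured compounds shown here, the one step measured between neighbouring structures, a number 8 percentage points lower from compound 2 to compound 3 (within the scatter), concerns the ring on the carbonyl carbon and stays within the scatter.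

Compound 4 `COc1ccc(-c2cc(/C=C/C(=O)c3ccc(N)cc3)[nH]n2)cc1OC` differs from compound 1 in one place: methoxy in place of hydrogen on an aromatic carbon. The new group sits ortho to a methoxy group already present, meta to a large group. For the measured compounds named here, no measured pair shows the effect of adding a methoxy group on this ring, so there is nothing to carry over, and the only measured step, on the other ring, was small. The step in this assay from compound 1 to compound 4 is therefore expected to stay within the scatter, a number 1 percentage points lower from compound 1 to compound 4 (within the scatter). For compound 4 the estimated value in this assay is 78%, with an expected range from 62% to 94%.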

Compound 4, a percentage reported as activity, at one concentration (the size of the read-out at that concentration, not a potency): 95%
Compound 4: the middle estimate sits 17 percentage points below what was measured; the whole stated range lies below it.
By their numbers in this assay, from the lowest: compounds 1, 3, 4 and 2 (each within the scatter of the next, the first and the last beyond it).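

Adding a methoxy group on this ring, ortho to the methoxy group already present and meta to a large group, gives a number 16 percentage points higher from compound 1 to compound 4 (beyond the scatter) in this assay, so the effect at the concentration tested is weaker. Among the compounds shown here, this position is therefore not indifferent to a change: a group of just 2 heavy atoms moves the read-out beyond the scatter, whereas the only earlier step, a number 8 percentage points lower from compound 2 to compound 3 (within the scatter), on the other ring, did not. No measurement at hand explains this step.

A single group at one position cannot show whether the size of the group or its oxygen matters, and a hydroxy group, a fluorine atom or an ethoxy group there could help separate the two. From the compounds shown here alone, it also remains open whether the same methoxy addition has a similar effect when the ring on the carbonyl carbon carries chlorine or fluorine atoms instead of the amine.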